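Pyrrole for pyrrolidine on the shared core: cytotoxicity

The source may hold more compounds than are shown below. What is called first, only, known or untested is meant among the compounds shown, and "the series" means these compounds.

Measured so far:
compound 1 `Cc1cc(N2CCCC2)c2ncc(CSCCc3ccccc3)n2c1`: > 100 ug/mL
compound 2 `Cc1cc(N2CCCC2)c2ncc(CSCc3ccccc3)n2c1`: 52 ug/mL

Two compounds of the shared core have been run in an ADME assay on HEL cells (Homo sapiens) for cytotoxicity, with a stated time of 3 days; on this read-out higher numbers stand for lower toxicity in this test and lower numbers for higher toxicity in this test. For compound 1 the read-out is a limit of the assay, > 100 ug/mL, so compound 1 stands only at the limit of > 100 ug/mL in this assay, at which 1 of the 2 values shown sits, and no exact number is known for it. Compound 2 gives 52 ug/mL. Among the measured compounds shown here, the single measured step, an at least 1.9-fold lower number from compound 1 to compound 2 (0.28 log units; that floor lies within the scatter), concerns the chain on the sulfur and not the amine ring on the core.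

Compound 3 `Cc1cc(-n2cccc2)c2ncc(CSCCc3ccccc3)n2c1` is not yet measured. It differs from compound 1 by 1H-pyrrol-1-yl in place of pyrrolidin-1-yl on an aromatic carbon. For the measured compounds named here, no measured step touches this position, and the one step that is known, toward compound 2, has a floor inside the scatter. There is therefore no measured basis for a shift in either direction, and the expectation for compound 3 is a step of about an at least 1.1-fold lower number from compound 1 to compound 3 (0.07 log units; that floor lies within the scatter), that is, none beyond the scatter. The estimate for compound 3 in this assay is 85 ug/mL. For compound 3 the expected range runs from 30 ug/mL to 200 ug/mL, with a fair chance that the assay again reports only a limit.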

Compound 3, half-maximal cytotoxic concentration: 26 ug/mL
For compound 3 the middle estimate is 3.3-fold (0.51 log units) above the measured one; measured number below the stated range.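

Among the compounds shown here, the amine ring on the aromatic carbon is the first place on the shared core to give a step beyond the scatter in this assay, where 1H-pyrrol-1-yl in place of pyrrolidin-1-yl gives an at least 3.8-fold lower number from compound 1 to compound 3 (0.58 log units; beyond the scatter). The two groups match in heavy atoms, hydrogen-bond donors and acceptors, and net charge, so the listed difference between them is that one ring is aromatic and the other non-aromatic, and at this position that exchange alone goes with a clearly lower number. The step is only a floor and its full size stays unknown because compound 1 is held at a limit of the assay: the limit of > 100 ug/mL in this assay, at which 1 of the 3 values shown sits.

Whether the same exchange lowers the number with the shorter sulfur chain of compound 2 remains open, since the aromatic ring is shown only with the longer chain. Also open is where other groups on this aromatic carbon, such as piperidin-1-yl, morpholin-4-yl, dimethylamino or an imidazol-1-yl ring, would fall relative to the two rings shown here.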